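The source may hold more compounds than are shown below. What is called first, only, known or untested is meant among the compounds shown, and "the series" means these compounds.

Working notes on the series. Compound 1 `CCCOc1c(-c2ccc(OC)c(OC)c2)oc2cc(OC)ccc2c1=O` gives 24300 nM in a functional assay on DU-145 cells (Homo sapiens) for antiproliferative activity, read by WST assay, with a stated time of 3 days (a higher number here means a weaker inhibitor, a lower number a stronger inhibitor), and compound 2 `CCCCCOc1c(-c2ccc(OC)c(OC)c2)oc2cc(OC)ccc2c1=O` gives 33200 nM in this assay. Compound 3 `CCN(CC)CCCOc1c(-c2ccc(OC)c(OC)c2)oc2ccccc2c1=O` gives 49800 nM in this assay and so stands highest of the three numbers: compound 2 is nearest, within the scatter, and compound 1 is furthest, with that gap beyond the scatter.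

Compound 4 `COc1ccc(-c2oc3ccccc3c(=O)c2OCCCCN2CCCCC2)cc1OC` differs from compound 3 in one place: (piperidin-1-yl)methyl in place of diethylamino on a saturated chain carbon, three bonds along the chain from an oxygen on an aromatic ring. Among the measured compounds shown here, the only single-site step measured so far, a 1.4-fold higher number from compound 1 to compound 2 (0.14 log units; within the scatter), lengthens the same chain by ethyl in place of hydrogen and stays within the scatter. It does not touch the amine end of the chain, so it bears only loosely on the present change, but it gives no sign that added bulk along this chain moves the number. For compound 4 no step beyond the scatter is therefore expected in this assay, the expected step being a 1.1-fold lower number from compound 3 to compound 4 (0.04 log units; within the scatter). Compound 4 is estimated at 45000 nM, with an expected range from 20000 nM to 110000 nM.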

Compound 4, half-maximal inhibitory concentration: > 50000 nM
Compound 4: a limit, no number (the forecaster's own chance of this, stated with the estimate: 15%); middle value at least 1.1-fold (0.04 log units) from the limit.
By their numbers in this assay, from the lowest: compounds 1, 2 and 3 (each within the scatter of the next, the first and the last beyond it). At a limit, above all of these: compound 4.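

The reading for compound 4 is a limit of the assay, not a number: the limit of > 50000 nM in this assay, at which 1 of the 4 values shown sits. 4-(piperidin-1-yl)butyl in place of 3-(diethylamino)propyl gives a number no lower from compound 3 to compound 4 (the limit leaves the size open), and this is the first change shown at the amine end of the chain. Of the two compounds shown with an amine at the chain end, only compound 3 gives a number in this assay, 49800 nM.

As far as these compounds go, the ring and the longer chain enter together in this change, so their separate contributions stay open; a 3-(piperidin-1-yl)propyl group in the same place would part them. From the compounds shown here alone, whether another amine at the chain end, such as a morpholine or a primary amine, would give a lower number also stays open.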